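Hydroxy in place of nitro: working notes

The source may hold more compounds than are shown below. What is called first, only, known or untested is meant among the compounds shown, and "the series" means these compounds.

Values in a functional assay on MGC-803 cells (Homo sapiens) for inhibition, read by MTT assay, with a stated time of 72 h; a higher number here means a weaker inhibitor, a lower number a stronger inhibitor:
Compound 1 `C#CCSc1nc(Nc2ccc(C)cc2)c2ccncc2n1`: 8090 nM
Compound 2 `C#CCSc1nc(Nc2ccc(F)cc2)c2ccncc2n1`: 15800 nM
Compound 3 `C#CCSc1nc(Nc2ccc([N+](=O)[O-])cc2)c2ccncc2n1`: > 80000 nM (a limit, not a number)

Compound 3 stands at the limit of > 80000 nM in this assay, at which 1 of the 3 values shown sits. Compound 4 `C#CCSc1nc(Nc2ccc(O)cc2)c2ccncc2n1` carries hydroxy in place of nitro on an aromatic carbon. Two measured steps bring in nitro: an at least 9.8-fold higher number from compound 1 to compound 3 (0.99 log units; beyond the scatter), and an at least 5.0-fold higher number from compound 2 to compound 3 (0.70 log units; beyond the scatter). Both lie beyond the scatter, while a 2.0-fold higher number from compound 1 to compound 2 (0.29 log units; within the scatter) stays within it. Hydroxy itself is unmeasured in this series, so compound 4 is expected to fall back towards the two measured values, by a step of similar size in this assay towards a lower number. The expected change is an at least 4.0-fold lower number from compound 3 to compound 4 (0.60 log units; beyond the scatter). For compound 4 the estimated value is 20000 nM, with an expected range of 6000 nM to 70000 nM.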

Compound 4, half-maximal inhibitory concentration: > 80000 nM
Compound 4 ended at the assay's limit; the forecaster's own chance of this, stated with the estimate: 15%; middle value at least 4.0-fold (0.60 log units) away from the limit.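

In this assay, hydroxy at this place, para to a large group, brings no return towards the methyl and fluoro compounds: the series shows an at least 9.8-fold higher number from compound 1 to compound 4 (0.99 log units; beyond the scatter) and an at least 5.0-fold higher number from compound 2 to compound 4 (0.70 log units; beyond the scatter). The step between compound 3 and compound 4 cannot be read, so nitro and hydroxy cannot be put in any order. Hydroxy thus stands with nitro at the same limit of the assay, not at a number: the limit of > 80000 nM in this assay, at which 2 of the 4 values shown sit.

Going by these compounds, how far beyond that limit either compound lies remains open. So does whether an amine or methoxy at this place would stay near compound 1 or join compound 4.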